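Phenyl-to-bromo swap across two amide cores: stability notes

The compounds below may be only part of what the source reports. "The series", "measured", "known", "first", "only" and "open" are said of these compounds alone.

Three compounds of the series have been run in an ADME assay on microsomes from liver (Homo sapiens) for metabolic stability; on this read-out lower numbers stand for a shorter-lived compound and higher numbers for a longer-lived compound. Compound 1 `CCCNC(=O)C1CC12CCN(C(=O)c1cc3sc(-c4ccccc4)nc3n1Cc1ccc(OC)cc1)CC2` gives 0.697 h. Compound 3 `CCCNC(=O)C1CC12CCN(C(=O)c1cc3sc(Br)nc3n1Cc1ccc(OC)cc1)CC2` carries the same amide-bearing core but differs from compound 1 in one place, (bromo in place of phenyl on an aromatic carbon), and in this assay compound 3 gives 0.0828 h. Among the compounds with values here, the step of an 8.4-fold lower number from compound 1 to compound 3 (0.93 log units; beyond the scatter) is the only measured instance of this change so far.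

Compound 2 `CCCNC(=O)[C@@H]1C[C@H]2CCC[C@@H](C1)[C@@H]2NC(=O)c1cc2sc(-c3ccccc3)nc2n1Cc1ccc(OC)cc1` is built on a different core; the difference between the two cores is not broken down here. In this assay compound 2 gives 0.453 h, which against compound 1 falls within the usual scatter, while against compound 3 it stands well beyond it.

Compound 4 `CCCNC(=O)[C@@H]1C[C@H]2CCC[C@@H](C1)[C@@H]2NC(=O)c1cc2sc(Br)nc2n1Cc1ccc(OC)cc1` has not yet been measured. It relates to compound 2 exactly as compound 3 relates to compound 1: bromo in place of phenyl on an aromatic carbon. The place description is the same word for word in both pairs, so this is the same change made on a second core. Within the data shown here, since compound 2 and compound 1 sit within scatter of each other, the step measured from compound 1 to compound 3 is taken as the best guide to what the same change will do from compound 2 to compound 4, with the understanding that only one prior instance exists and a different core may respond differently.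

On that basis the step from compound 2 to compound 4 in this assay is expected to be about an 8.4-fold lower number from compound 2 to compound 4 (0.92 log units; beyond the scatter), because of an 8.4-fold lower number from compound 1 to compound 3 (0.93 log units; beyond the scatter). Compound 4 is therefore estimated at 0.054 h, with a plausible range from 0.025 h to 0.12 h.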

Compound 4, half-life: 0.867 h
Estimate against measurement, compound 4: 16-fold (1.21 log units) below, outside the stated range (above it).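

On the core of compound 2, bromo in place of phenyl on an aromatic carbon gives a 1.9-fold higher number from compound 2 to compound 4 (0.28 log units; within the scatter) in this assay. Set beside the step on the core of compound 1, the same change does not carry over from one core to the other in this assay: the same change on two cores in this assay, an 8.4-fold lower number (0.93 log units; beyond the scatter) from compound 1 to compound 3 and a 1.9-fold higher number (0.28 log units; within the scatter) from compound 2 to compound 4, 16-fold (1.21 log units) apart, beyond the scatter of two such steps

This shows that, within these two pairs, the outcome of the swap depends on the core it is made on, so a step measured on one core is a poor guide to the other. Within the data shown here, it does not show which part of the two cores accounts for the gap, since there is only one pair per core, and it gives no basis for predicting the step on any third core.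

The compounds shown leave open whether the same dependence on the core appears with other groups on this aromatic carbon, such as chloro, methyl or an amine in place of bromo. They also leave open whether the gap between the two cores persists when the propyl chain on the amide gives way to a longer chain.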